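Sulfonamide series: one chloro removed from the benzyl ring

The compounds below may be only part of what the source reports. "The series", "measured", "known", "first", "only" and "open" are said of these compounds alone.

Of the compounds shown here, two have numbers so far. Compound 1 `CC(C)(C)c1ccc(CNCCCNS(=O)(=O)c2cc(C(F)(F)F)cc(C(F)(F)F)c2)cc1` gives 2300 nM in a functional assay on HPAC cells (Homo sapiens) for inhibition, read by MTT assay, with a stated time of 72 h (on this read-out lower numbers stand for stronger inhibition of growth and higher numbers for weaker inhibition of growth), and compound 2 `O=S(=O)(NCCCNCc1ccc(Cl)c(Cl)c1)c1cc(C(F)(F)F)cc(C(F)(F)F)c1` gives 2500 nM in this assay. Among the measured compounds shown here, the one step between them, a 1.1-fold higher number from compound 1 to compound 2 (0.04 log units; within the scatter), exchanges the whole aryl group on the benzyl carbon and yet stays within the scatter. For the measured compounds named here, compound 2 thus stands at the higher of the two numbers, with compound 1 as its only neighbour, the gap between them within the scatter.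

The next compound, compound 3 `O=S(=O)(NCCCNCc1ccc(Cl)cc1)c1cc(C(F)(F)F)cc(C(F)(F)F)c1`, differs from compound 2 by hydrogen in place of chloro on an aromatic carbon. Going by the values given here, no measured step removes a single ring chloro, so the only bearing comes from the step from compound 1 to compound 2, which shows that a large change of the aryl substitution left the number essentially unmoved. A change that keeps the 4-chlorophenyl group and only drops the second chloro is expected to do no more. For compound 3 the estimated step is a 1.2-fold higher number from compound 2 to compound 3 (0.08 log units; within the scatter), no more than the scatter, if anything toward a slightly higher number. Compound 3 is therefore expected to give about 3000 nM, with a plausible range from 1500 nM to 6500 nM.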

Compound 3, concentration for 50% growth inhibition: 2800 nM
Beside the measured number, compound 3's estimate is 1.1-fold (0.03 log units) above it; the measured number falls inside the stated range.
By their numbers in this assay, from the lowest: compounds 1, 2 and 3 (each within the scatter of the next).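

In this assay, among the compounds shown here, the step to hydrogen on this aromatic carbon, a 1.1-fold higher number from compound 2 to compound 3 (0.05 log units; within the scatter), is the first reading of a single ring chloro on its own: the 3,4-dichlorophenyl and 4-chlorophenyl compounds cannot be told apart, so the second chloro shows no measurable weight. The other new step, a 1.2-fold higher number from compound 1 to compound 3 (0.09 log units; within the scatter), puts chloro in place of tert-butyl on an aromatic carbon and also stays within the scatter, so all three aryl groups shown now read alike on this growth read-out, a statement that holds for these compounds only. Nothing available explains why the number stays so flat across these changes.

Still open, on these data alone, is whether the aryl substitution matters at all, which an unsubstituted benzyl group or a pyridylmethyl group would test against the chlorinated compounds. Also open, as far as these compounds go, is whether any part of the core moves the number, as a longer chain in place of the present one, or an amide in place of the amine, might show.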